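Hydrazone glucosides: pentyl in place of 3-cyanophenyl

This account rests on a few compounds, and the source may have more. Where it says the series, first, only, none or still open, it means among the compounds named here.

Working notes on two measured glucoside analogues and one untested variant. In a functional assay on MDA-MB-231 cells (Homo sapiens) for inhibition, read by MTT assay, with a stated time of 24 h, tested at 100 uM (on this read-out lower numbers stand for less inhibition and higher numbers for more inhibition at the one concentration tested (going by the name of the read-out)), compound 1 `N#Cc1cccc(/C=N/NC(=O)c2ccc(O[C@@H]3O[C@H](CO)[C@@H](O)[C@H](O)[C@H]3O)cc2)c1` gives 6.17%. Compound 2 `CCCCCc1nnc(-c2ccc(O[C@@H]3O[C@H](COC(C)=O)[C@@H](OC(C)=O)[C@H](OC(C)=O)[C@H]3OC(C)=O)cc2)o1` gives 21.5% in this assay. Among the compounds with values here, compound 1 therefore stands lowest of the two numbers, and the gap to compound 2 lies beyond the scatter; no step between compounds differing in a single place is available, as these two differ in several places at once. Compound 3 `CCCCC/C=N/NC(=O)c1ccc(O[C@@H]2O[C@H](CO)[C@@H](O)[C@H](O)[C@H]2O)cc1` is the untested variant of compound 1 with pentyl in place of 3-cyanophenyl on a carbon with a double bond to nitrogen. Within the data shown here, no measured pair shows what this swap does, so the only anchor is the weak reading of compound 1 at 6.17%. A small step, a number 3.8 percentage points higher from compound 1 to compound 3 (within the scatter), that stays within the scatter is expected. Compound 3 is accordingly expected at 10%, with a range from 0% to 25%.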

Compound 3, a percentage reported as inhibition, at one concentration (the size of the read-out at that concentration, not a potency): 11%
Compound 3: middle estimate off by 1 percentage points, on the low side, within the range that was stated.
By their numbers in this assay, from the lowest: compounds 1 and 3 (each within the scatter of the next); then compound 2.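

In this assay, the series now has its first step in a single place: pentyl in place of 3-cyanophenyl, on a carbon with a double bond to nitrogen, gives a number 4.8 percentage points higher from compound 1 to compound 3 (within the scatter). At this position, then, an open chain and an aromatic ring carrying a nitrile read alike, and neither the ring nor the nitrile is required for a reading of this size on the core of compound 1. No measurement shown here accounts for this result.

From the compounds shown here alone, whether a longer chain or a carboxylic acid in place of pentyl on that carbon would separate from compound 1 remains open. Going by these compounds, compound 2 differs from compound 3 in several places at once, so which of those differences goes with its reading also remains open.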